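This account rests on a few compounds, and the source may have more. Where it says the series, first, only, none or still open, it means among the compounds named here.

Compound 1, `CCn1cc(CN2CCN(c3cccn4cc(-c5ccc(C(C)(C)C)cc5)nc34)CC2)c(=O)[nH]c1=O`: 260 nM. Compound 2, `CC(C)(C)c1ccc(-c2cn3cccc(N4CCN(Cc5cnc6ccccc6n5)CC4)c3n2)cc1`: 1500 nM.

In a functional assay on cells (Pituitary gland cell) for antagonist activity at Gonadotropin-releasing hormone receptor (Rattus norvegicus), read by immunoassay, with a stated time of 3 h (a higher number here means a weaker inhibitor, a lower number a stronger inhibitor), compound 1 gives 260 nM, the lower of the two numbers, so it is the stronger inhibitor of this pair. Compound 3, `CC(C)(C)c1ccc(-c2cn3cccc(N4CCN(Cc5ccc6nccnc6c5)CC4)c3n2)cc1`, is not yet measured. It differs from compound 1 by a group of 10 heavy atoms (8 carbon, 2 nitrogen; one six-membered aromatic ring of carbon only, one six-membered aromatic ring with 2 hetero atoms) in place of a group of 10 heavy atoms (6 carbon, 2 nitrogen, 2 oxygen; one six-membered aromatic ring with 2 hetero atoms), on a saturated chain carbon bound to an amine nitrogen in a ring. Within the data shown here, one measured step bears on this: a 5.8-fold higher number from compound 1 to compound 2 (0.76 log units; beyond the scatter), the same kind of exchange at the same place, with an entering group counted the same way. For compound 3 a loss of similar size is therefore expected, beyond the scatter, a 4.6-fold higher number from compound 1 to compound 3 (0.66 log units; beyond the scatter). For compound 3 the estimate in this assay is 1200 nM, within 400 nM to 4000 nM.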

Compound 3, half-maximal inhibitory concentration: 3400 nM
Beside the measured number, compound 3's estimate is 2.8-fold (0.45 log units) below it, and the stated range covers the measured number.
By their numbers in this assay, from the lowest: compound 1; then compound 2; then compound 3.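

In this assay, quinoxalin-6-yl at this place costs more than the earlier exchange did, with a 13-fold higher number from compound 1 to compound 3 (1.12 log units; beyond the scatter), so the loss from leaving compound 1 depends on which group enters. The attachment point on the quinoxaline also counts: moving from quinoxalin-2-yl to quinoxalin-6-yl gives a 2.3-fold higher number from compound 2 to compound 3 (0.36 log units; beyond the scatter), although both groups have the same atoms. No measurement shown gives a reason for these differences. On these data alone, whether a single phenyl ring or a pyridine ring on this carbon would come closer to compound 1 remains open.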